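A few compounds are considered here, and "the series" means these few. Any claim that something is new, unique, unknown or untested is made for them only; others in the source may bear on it.

Measured compounds in an in vitro assay on HEK385-7 cells for displacement of a labelled ligand from prostaglandin D2 receptor 2 (Homo sapiens); a higher number here means a weaker inhibitor, a lower number a stronger inhibitor:

- compound 1, `O=C(O)Cc1sc(C(c2ccc(F)cc2)c2ccc(F)cc2)nc1-c1cccc(F)c1`, 1.4 nM
- compound 2, `Cc1cc(-c2nc(C(c3ccc(F)cc3)c3ccc(F)cc3)sc2CC(=O)O)ccn1`, 3.1 nM

For the measured compounds named here, compound 2 stands at the higher of the two numbers; the only neighbour is compound 1, and the one measured step, a 2.2-fold higher number from compound 1 to compound 2 (0.35 log units; beyond the scatter), lies beyond the scatter but is modest in size.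

Compound 3, `CN(C)c1cc(-c2nc(C(c3ccc(F)cc3)c3ccc(F)cc3)sc2CC(=O)O)ccn1`, is not yet measured. It differs from compound 2 in one place: dimethylamino in place of methyl on an aromatic carbon. Going by the values given here, the only step in hand, from compound 1 to compound 2, exchanges the whole aryl group on the shared core and therefore does not speak to a change kept within the 2-methylpyridin-4-yl group. Among the compounds with values here, no measured pair shows what replacing the methyl by dimethylamino does here. With nothing to set the direction, the expectation for compound 3 is a step not clearly beyond the scatter, a 1.1-fold higher number from compound 2 to compound 3 (0.05 log units; within the scatter), with a wide range to either side. Compound 3 is estimated at 3.5 nM in this assay, between 1.2 nM and 10 nM.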

Compound 3, half-maximal inhibitory concentration: 380 nM
Beside the measured number, compound 3's estimate is 110-fold (2.04 log units) below it; the whole stated range lies below it.
By their numbers in this assay, from the lowest: compound 1; then compound 2; then compound 3.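

Working notes on the series: in this assay, the aromatic carbon next to the ring nitrogen proves highly sensitive to its substituent, with dimethylamino in place of methyl giving a 120-fold higher number from compound 2 to compound 3 (2.09 log units; beyond the scatter), a large step. The earlier exchange of the whole aryl group for 2-methylpyridin-4-yl moved the number only modestly (a 2.2-fold higher number from compound 1 to compound 2 (0.35 log units; beyond the scatter)), so the small change within that group counts for far more here than the larger exchange did. The 2-(dimethylamino)pyridin-4-yl group also falls well short of 3-fluorophenyl (a 270-fold higher number from compound 1 to compound 3 (2.43 log units; beyond the scatter)), and no measurement at hand accounts for the size of these steps.

Still open, going by these compounds, is whether a primary amine, a methylamino group or a methoxy group on this same carbon would stay close to compound 2 (3.1 nM) or show a similar large step, which would separate the effect of the attached nitrogen from that of the two methyl groups on it. Also open, on these data alone, is whether a longer alkyl chain such as ethyl is accepted here, and whether an unsubstituted pyridin-4-yl group matches the methyl-bearing one.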